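Moving an ethyl group around the ring: compound 2 to compound 4

This account rests on a few compounds, and the source may have more. Where it says the series, first, only, none or still open, it means among the compounds named here.

Of the compounds shown here, three have been tested so far in a functional assay on NCI-H1581 cells (Homo sapiens) for inhibition, read by MTT assay, with a stated time of 48 h, tested at 10 uM; a higher number here means more inhibition at the concentration tested (going by the name of the read-out), a lower number less inhibition. Compound 1 `CCc1ccc(Nc2cc(NC(=O)Nc3c(Cl)cccc3Cl)ncn2)cc1` gives 38.1% in this assay. Compound 3 `COc1ccc(C(F)(F)F)cc1Nc1cc(NC(=O)Nc2c(Cl)cccc2Cl)ncn1` reaches 69.1% in this assay, the highest of the three. Compound 2 `CCc1cccc(Nc2cc(NC(=O)Nc3cc(OC)cc(OC)c3)ncn2)c1` gives 27.7% in this assay, the lowest of the three numbers; its nearest neighbour is compound 1, whose number lies beyond the scatter above it, and compound 3 stands furthest above it.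

Compound 4 `CCc1ccc(Nc2cc(NC(=O)Nc3cc(OC)cc(OC)c3)ncn2)cc1` has not been measured. It shares every atom with compound 2, joined differently: 4-ethylphenyl in place of 3-ethylphenyl on a nitrogen on an aromatic ring. Within the data shown here, no measured pair shows this change on its own, so the expected step from compound 2 to compound 4 rests only on the general spread of the three numbers. The step of a number 4.3 percentage points higher from compound 2 to compound 4 (within the scatter) is expected to be small and upward, most likely within the scatter. Compound 4 is therefore estimated at 32% in this assay, with a range from 15% to 50%.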

Compound 4, a percentage reported as inhibition, at one concentration (the size of the read-out at that concentration, not a potency): 32.7%
For compound 4 the middle estimate is 0.7 percentage points below the measured one; low and high end bracket the measured number.
By their numbers in this assay, from the lowest: compounds 2, 4 and 1 (each within the scatter of the next, the first and the last beyond it); then compound 3.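

In this assay, among these compounds, moving the ethyl group gives a number 5 percentage points higher from compound 2 to compound 4 (within the scatter), the first comparison here in which only one place changes. With everything else held the same, 4-ethylphenyl in place of 3-ethylphenyl on a nitrogen on an aromatic ring therefore leaves the read-out indistinguishable from the usual variation between repeats, so these two ethyl placements cannot be told apart in this test. Nothing available here bears on the reason for this result.

The compounds shown leave open whether the ethyl group itself matters, since neither plain phenyl nor a longer chain such as propyl appears at this place. They also leave open whether the same move would do as little when paired with the other end of the molecule found in compound 1.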